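Shifting a Chlorine Within a Shared Scaffold

The source may hold more compounds than are shown below. What is called first, only, known or untested is meant among the compounds shown, and "the series" means these compounds.

Compound 1 `Clc1cccc(-c2cc(-c3ccc(Cl)o3)cc(-c3cccs3)n2)c1` was tested in a functional assay on HCT-15 cells (Homo sapiens) for cytotoxicity, in the presence of a further agent that is not named here (a lower number here means a stronger inhibitor, a higher number a weaker inhibitor), where compound 1 gives 15500 nM. Compound 2 `Clc1ccc(-c2cc(-c3cccnc3)nc(-c3ccsc3)c2)o1` reaches only a limit of this assay, > 50000 nM. Compound 1 therefore stands as the only actual number shown, the other value sitting at a limit (the limit of > 50000 nM in this assay, at which 1 of the 2 values shown sits). Compound 3 `Clc1ccc(-c2cc(-c3cccs3)nc(-c3ccccc3Cl)c2)o1` has not yet been measured; it differs from compound 1 by 2-chlorophenyl in place of 3-chlorophenyl on an aromatic carbon. Going by the values given here, no measured pair shows this change, so no step beyond the usual scatter is expected in this assay. Compound 3 is estimated at 20000 nM, between 7000 nM and 60000 nM, an expected step of a 1.3-fold higher number from compound 1 to compound 3 (0.11 log units; within the scatter).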

Compound 3, half-maximal inhibitory concentration: 6190 nM
For compound 3 the middle estimate is 3.2-fold (0.51 log units) above the measured one; measured number outside the range, below it.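

Moving the chlorine from 3-chlorophenyl to 2-chlorophenyl keeps the same atoms, yet it gives a 2.5-fold lower number from compound 1 to compound 3 (0.40 log units; beyond the scatter) in this assay, a modest step. Going by these compounds alone, on this aromatic carbon next to the ring nitrogen, then, where the chlorine sits on the phenyl ring changes the read-out, something the earlier compounds could not show. Nothing given here explains this difference.

Going by these compounds, whether a methoxy group or an amine in place of the chlorine would lower the number further remains open. So does whether the same shift would give a similar step on a different core.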